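Urea aryl swap: chloro to trifluoromethyl in compound 4

The compounds below may be only part of what the source reports. "The series", "measured", "known", "first", "only" and "open" are said of these compounds alone.

Notes on the series. Compound 1 `O=C(Nc1cccc(-n2cc(-c3ccncc3)c(-c3ccc(Cl)c(O)c3)n2)c1)Nc1ccc(Cl)c(Cl)c1` in a functional assay on LOX IMVI cells (Homo sapiens) for inhibition, read by sulforhodamine B assay, with a stated time of 48 h (on this read-out lower numbers stand for higher toxicity in this test and higher numbers for lower toxicity in this test), gives 15000 nM. Compound 3 `O=C(Nc1cccc(-n2cc(-c3ccncc3)c(-c3ccc(Cl)c(O)c3)n2)c1)Nc1cc(C(F)(F)F)cc(C(F)(F)F)c1` gives 2750 nM in this assay. Compound 1 thus holds the higher of the two measured numbers, and its gap to compound 3 lies beyond the scatter. Compound 2 `COc1cc(-c2nn(-c3cccc(NC(=O)c4cccc(C(F)(F)F)c4)c3)cc2-c2ccncc2)ccc1Cl` reaches the assay limit of > 50000 nM in this assay, a limit and not a number. One value in the set sits at the limit of > 50000 nM in this assay, at which 1 of the 3 values shown sits.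

Compound 4 `O=C(Nc1cccc(-n2cc(-c3ccncc3)c(-c3ccc(Cl)c(O)c3)n2)c1)Nc1ccc(Cl)c(C(F)(F)F)c1` is not yet measured. Relative to compound 1 it changes by trifluoromethyl in place of chloro on an aromatic carbon. Among the measured compounds shown here, no step between measured compounds covers this change, so its size is uncertain; the only measured urea carrying trifluoromethyl on that ring is compound 3, which bears two of them and gives 2750 nM. For compound 4 the step of a 2.5-fold lower number from compound 1 to compound 4 (0.40 log units; beyond the scatter) is expected to run toward lower numbers, by an amount near the edge of the scatter or somewhat beyond it. Compound 4 is therefore estimated at 6000 nM, within 2500 nM to 14000 nM.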

Compound 4, concentration lethal to 50% of the cells: 2390 nM
Beside the measured number, compound 4's estimate is 2.5-fold (0.40 log units) above it, outside the stated range (below it).
By their numbers in this assay, from the lowest: compounds 4 and 3 (each within the scatter of the next); then compound 1. At a limit, above all of these: compound 2.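

With the rest of compound 1 held constant, trifluoromethyl in place of chloro on this aromatic carbon, ortho to a chloro group, gives in this assay a 6.3-fold lower number from compound 1 to compound 4 (0.80 log units; beyond the scatter). Among the compounds shown here, this is the first step that isolates a single place, and it shows that this position of the 3,4-dichlorophenyl ring responds to the change, with one trifluoromethyl group enough to move the number beyond the scatter. No measurement at hand gives a cause for this step.

Open, going by these compounds, is whether the step is particular to trifluoromethyl, or whether a methyl, a methoxy or a nitrile on the same carbon would move the number as well. Also open, on these data alone, is what happens when the remaining chloro group gives way to fluoro or to hydrogen.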